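A Methyl-to-Chloro Step Carried Across Two Cores

The compounds below may be only part of what the source reports. "The series", "measured", "known", "first", "only" and "open" are said of these compounds alone.

The study holds two pairs of compounds, each pair joined by one change. Compound 1 `Cc1ccc(-c2nn(-c3ccc(Br)cc3)c(/N=C/N(C)C)c2C=O)cc1` in a functional assay on Jurkat cells (Homo sapiens) for inhibition, read by MTT assay, with a stated time of 72 h (on this read-out higher numbers stand for weaker inhibition of growth and lower numbers for stronger inhibition of growth), gives 6700 nM, and compound 2 `CN(C)/C=N/c1c(C=O)c(-c2ccc(Cl)cc2)nn1-c1ccc(Br)cc1` in this assay gives 38900 nM; the change between them is chloro in place of methyl on an aromatic carbon, and it made a 5.8-fold higher number from compound 1 to compound 2 (0.76 log units; beyond the scatter). Compound 3 `Cc1ccc(-c2nn(-c3cccc(Cl)c3)c(N)c2C=O)cc1` rests on a second core, and in this assay compound 3 gives 86300 nM, the highest of the three numbers. How the core of compound 3 differs from that of compound 1 is not broken down here. Compound 4 `Nc1c(C=O)c(-c2ccc(Cl)cc2)nn1-c1cccc(Cl)c1` carries the same change, (chloro in place of methyl on an aromatic carbon), at a place described in the same words. The expectation rests on a 5.8-fold higher number from compound 1 to compound 2 (0.76 log units; beyond the scatter). For compound 4 the expected step is a 2.9-fold higher number from compound 3 to compound 4 (0.46 log units; beyond the scatter). Compound 4 is therefore expected to give about 250000 nM, between 70000 nM and 700000 nM.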

Compound 4, concentration for 50% growth inhibition: 78900 nM
Compound 4: middle estimate off by 3.2-fold (0.50 log units), on the high side, and the stated range covers the measured number.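

In this assay, going from 4-methylphenyl to 4-chlorophenyl on the second core gives a 1.1-fold lower number from compound 3 to compound 4 (0.04 log units; within the scatter), so the clear step seen on the first core does not reappear here. The change therefore did not carry over from one core to the other with the same size: the same change on two cores in this assay, a 5.8-fold higher number (0.76 log units; beyond the scatter) from compound 1 to compound 2 and a 1.1-fold lower number (0.04 log units; within the scatter) from compound 3 to compound 4, 6.4-fold (0.80 log units) apart, beyond the scatter of two such steps. This shows that, in these two pairs, the step from methyl to chloro cannot simply be transferred between the cores, but it does not show which difference between the cores is responsible, and two pairs set no rule for the series.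

The compounds shown leave open which part of the cores governs the size of the step. They also leave open how a methoxy group or an amine in the same place would behave on either core.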